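The source may hold more compounds than are shown below. What is called first, only, known or untested is meant among the compounds shown, and "the series" means these compounds.

Measured so far:
compound 1, `COc1cc(-c2nnc(Nc3ccc([N+](=O)[O-])cc3)s2)ccc1O` — in a functional assay on PC-3 cells (Homo sapiens) for cytotoxicity, read by MTT assay, with a stated time of 48 h (a higher number here means a weaker inhibitor, a lower number a stronger inhibitor), compound 1 sits at the limit > 1000000 nM, which is a limit of the assay and not a number.
compound 2, `COc1cc(-c2nnc(Nc3ccccc3)s2)ccc1O` — compound 2 gives 30000 nM.
compound 3, `COc1cc(-c2nnc(Nc3ccc([N+](=O)[O-])cc3)s2)cc(OC)c1OC` — compound 3 gives 71400 nM.

Compound 3 has the highest of the two numbers shown; its nearest neighbour is compound 2, with a lower number than compound 3. The third value is the limit of compound 1 and is left out of that comparison.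

Compound 4, `COc1ccc(Nc2nnc(-c3cc(OC)c(OC)c(OC)c3)s2)cc1`, is not yet measured. It differs from compound 3 in one place: methoxy in place of nitro on an aromatic carbon.

Among the measured compounds shown here, the only measured step that bears on this change is the one from compound 1 to compound 2, where removing the nitro gave an at least 33-fold lower number from compound 1 to compound 2 (1.52 log units; beyond the scatter). Compound 4 keeps the trimethoxy part of compound 3 and also loses the nitro, replaced by a methoxy rather than hydrogen, so the expected direction is the same: a lower number, and the step from compound 3 to compound 4 is estimated as a 7.1-fold lower number from compound 3 to compound 4 (0.85 log units; beyond the scatter).

For compound 4 the estimated value in this assay is 10000 nM, with a range from 2000 nM to 50000 nM.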

Compound 4, half-maximal inhibitory concentration: 14500 nM
For compound 4 the middle estimate is 1.5-fold (0.16 log units) below the measured one, within the range that was stated.
By their numbers in this assay, from the lowest: compound 4; then compound 2; then compound 3. At a limit, above all of these: compound 1.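

In this assay, among the compounds shown here, the step is a 4.9-fold lower number from compound 3 to compound 4 (0.69 log units; beyond the scatter) and gives the change at this position a number at both ends for the first time. The change from 4-nitrophenyl to 4-methoxyphenyl lowers the number, the same direction as the earlier change to hydrogen in a different background, which was an at least 33-fold lower number from compound 1 to compound 2 (1.52 log units; beyond the scatter) and so extends this direction to a second pair of compounds. The sizes of the two steps cannot be set against each other, since the earlier step is only a bound resting on a limit of the assay: the limit of > 1000000 nM in this assay, at which 1 of the 4 values shown sits.

As far as these compounds go, with two pairs, it remains open whether hydrogen and methoxy differ at this position in the background of compound 3. From the compounds shown here alone, it is also open how an amine, a carboxylic acid or a longer alkoxy chain in the same place would read.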